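Methyl-to-Chloro Exchange on the Thiosemicarbazone Aryl Group

A few compounds are considered here, and "the series" means these few. Any claim that something is new, unique, unknown or untested is made for them only; others in the source may bear on it.

Measured compounds:
Compound 1, `O=C1/C(=N\NC(=S)Nc2ccc(Cl)cc2)c2cc(F)ccc2N1Cc1ccc(F)cc1`: 47000 nM
Compound 2, `Cc1ccc(NC(=S)N/N=C2\C(=O)N(Cc3ccc(F)cc3)c3ccc(F)cc32)cc1`: 1500 nM
Compound 3, `Cc1ccc(NC(=S)N/N=C2\C(=O)N(Cc3ccc(Cl)cc3)c3ccc(Br)cc32)cc1`: 288000 nM

All three were tested in a functional assay on MOLT-4 cells (Homo sapiens), with a stated time of 72 h; a lower number here means a stronger inhibitor, a higher number a weaker inhibitor. Compound 2 and compound 1 share one core and differ only by chloro in place of methyl on an aromatic carbon; this change produced a 31-fold higher number from compound 2 to compound 1 (1.50 log units; beyond the scatter). Compound 3 gives 288000 nM, the highest number of the three; the difference between its core and that of compound 2 is not broken down here.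

Compound 4, `O=C1/C(=N\NC(=S)Nc2ccc(Cl)cc2)c2cc(Br)ccc2N1Cc1ccc(Cl)cc1`, has not yet been measured. It stands to compound 3 as compound 1 stands to compound 2: the change is chloro in place of methyl on an aromatic carbon, the same change as before, made at the same place.

Since compound 3 is already a very weak inhibitor in this assay, the writer expects compound 4 to be weaker still, though a value this high may come back only as a limit. For compound 4 the expected step is a 2.1-fold higher number from compound 3 to compound 4 (0.32 log units; beyond the scatter), resting on compound 2 and compound 1 because a 31-fold higher number from compound 2 to compound 1 (1.50 log units; beyond the scatter) went the same way. Compound 4 is estimated at 600000 nM, between 150000 nM and 3000000 nM.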

Compound 4, half-maximal inhibitory concentration: 280000 nM
For compound 4 the middle estimate is 2.1-fold (0.33 log units) above the measured one; low and high end bracket the measured number.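

In this assay, exchanging methyl for chloro gave a 1.0-fold lower number from compound 3 to compound 4 (0.01 log units; within the scatter), so on the core shared by compound 3 and compound 4 the exchange left the read-out without a measurable change. The large rise seen with the same exchange on the other core did not carry over, and the two steps clearly disagree: the same change on two cores in this assay, a 31-fold higher number (1.50 log units; beyond the scatter) from compound 2 to compound 1 and a 1.0-fold lower number (0.01 log units; within the scatter) from compound 3 to compound 4, 32-fold (1.51 log units) apart, beyond the scatter of two such steps. This shows that the effect of the exchange cannot be assumed to transfer from one core to the other in this series, but it does not show why, since the two cores differ in more than one place and these pairs cannot tell which difference matters.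

The compounds shown leave open how the exchange would behave on a core that differs from either of these in one place only. Also open, going by these compounds, is how other groups in place of the methyl of the 4-methylphenyl group, such as a methoxy group, a dimethylamino group or a carboxylic acid, would read on each core.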